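This account rests on a few compounds, and the source may have more. Where it says the series, first, only, none or still open, it means among the compounds named here.

Working notes on a small series assessed in a functional assay on NCI-H2122 cells (Homo sapiens) for inhibition, read by microscopy, with a stated time of 10 days; on this read-out lower numbers stand for stronger inhibition and higher numbers for weaker inhibition. Compound 1 `Cc1nn(C)c2c1C(c1ccc(OC(F)(F)F)cc1)C(C#N)=C(N)O2` gives 2900 nM in this assay. Compound 2 `Cn1nc(-c2ccccc2)c2c1OC(N)=C(C#N)C2c1ccc(OC(F)(F)F)cc1` carries the change phenyl in place of methyl on an aromatic carbon relative to compound 1. In this assay compound 2 gives 5500 nM. The step of a 1.9-fold higher number from compound 1 to compound 2 (0.28 log units; within the scatter) is within the scatter, so no order can be read from this pair. Compound 3 `Cc1nn(C)c2c1C(c1cccc(Br)n1)C(C#N)=C(N)O2` gives 2400 nM in this assay. The difference between the core of compound 3 and the core of compound 1 is not broken down here; the two values of compound 3 and compound 1 lie within the scatter of each other, while the gap from compound 3 to compound 2 lies beyond it. Compound 4 `Cn1nc(-c2ccccc2)c2c1OC(N)=C(C#N)C2c1cccc(Br)n1` has not yet been measured. It differs from compound 3 by phenyl in place of methyl on an aromatic carbon, the same change already seen between compound 1 and compound 2, at a place described in the same words; among the compounds shown this change occurs twice in all, and only one of the two occurrences has a number. Among the measured compounds shown here, the expected step is a 1.9-fold higher number from compound 3 to compound 4 (0.27 log units; within the scatter), and this expectation rests on the single earlier step of a 1.9-fold higher number from compound 1 to compound 2 (0.28 log units; within the scatter). That earlier step is within the scatter, so only a small shift toward a higher number is expected, with wide uncertainty around it. Compound 4 is accordingly estimated at 4500 nM in this assay, with an expected range from 2200 nM to 9500 nM.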

Compound 4, half-maximal inhibitory concentration: 1700 nM
The estimate for compound 4 lay 2.6-fold (0.42 log units) above the measured number; the measured number lies below the stated range.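

In this assay, phenyl in place of methyl on an aromatic carbon gives a 1.4-fold lower number from compound 3 to compound 4 (0.15 log units; within the scatter), so on the core of compound 3 this step alone sets no order between its two compounds, and the same holds for the earlier pair on the core of compound 1. Set side by side, however, the two occurrences of the change do not agree, and the gap between them is larger than the scatter allows: the same change on two cores in this assay, a 1.9-fold higher number (0.28 log units; within the scatter) from compound 1 to compound 2 and a 1.4-fold lower number (0.15 log units; within the scatter) from compound 3 to compound 4, 2.7-fold (0.43 log units) apart, beyond the scatter of two such steps This shows that the step seen on the core of compound 1 cannot simply be carried over to the core of compound 3, so the effect of this change depends on the core in these two pairs; it does not show that phenyl is better or worse than methyl on either core, it gives no reason for the difference, and two occurrences set no rule for the wider series.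

The compounds shown hold only methyl and phenyl at this place, so it remains open how an ethyl, a cyclopropyl, an amine or a pyridyl ring would behave there. On these data alone, it also remains open whether the same disagreement between steps would appear on cores other than those of compound 1 and compound 3.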